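Changing the acid of compound 1 to an amide

This account rests on a few compounds, and the source may have more. Where it says the series, first, only, none or still open, it means among the compounds named here.

In a functional assay on the whole organism for inhibition, with Rattus norvegicus as the target, read by paw edema, with stated times of 1 h and 3 h (on this read-out lower numbers stand for an effect already at smaller amounts and higher numbers for an effect only at larger amounts of compound), compound 1 (`C/C(=N\OCC(=O)O)c1ccc(Br)cc1`) gives 27 mg/kg and compound 3 (`O=C(O)CO/N=C/c1ccc(Br)cc1`) gives 46 mg/kg as its result, two values within the usual scatter of each other. Compound 2 (`C/C(=N\OCC(=O)O)c1ccc(C(F)(F)F)cc1`) gives 120 mg/kg in the same test. The step of a 4.4-fold higher number from compound 1 to compound 2 (0.65 log units; beyond the scatter) stands apart from compound 1 by more than the scatter. Compound 4 (`C/C(=N\OCC(N)=O)c1ccc(Br)cc1`) is still unmeasured and carries amino in place of hydroxy on a carbonyl carbon. For the measured compounds named here, that measured step sits on an aromatic carbon, so no measured pair shows this change directly. A modest rise in the number is therefore only a cautious expectation. The estimated step runs a 1.9-fold higher number from compound 1 to compound 4 (0.27 log units; within the scatter) as a best guess. Compound 4 is expected at 50 mg/kg within an estimated range of 15 mg/kg to 170 mg/kg in this assay overall.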

Compound 4, dose for half-maximal effect: 62 mg/kg
The estimate for compound 4 lay 1.2-fold (0.09 log units) below the measured number, within the range that was stated.
By their numbers in this assay, from the lowest: compounds 1, 3, 4 and 2 (each within the scatter of the next, the first and the last beyond it).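

In this assay, for the compounds shown here, putting amino in place of hydroxy on a carbonyl carbon gives a 2.3-fold higher number from compound 1 to compound 4 (0.36 log units; beyond the scatter), the first measured change at this position. Carboxy can therefore give way to carbamoyl with the effect retained, although a larger dose is needed. No measured information here explains this shift. Going by these compounds, what remains open is how other groups would fare in this place, for example a methyl ester or a hydroxamic acid. Whether such a group would bring the number back towards that of compound 1 also remains unanswered.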